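The compounds below may be only part of what the source reports. "The series", "measured", "known", "first", "only" and "open" are said of these compounds alone.

Working notes on the series. Compound 1 `CCCCCCCCCCCC/C=C\[C@@H](SC[C@H](N)C(=O)NCC(=O)O)[C@@H](O)CCC(=O)O` and compound 2 `CCCCCCCCCCCC/C=C\[C@H](SC[C@H](N)C(=O)NCC(=O)O)[C@H](O)CCC(N)=O` share a core and differ in the terminal group of the side chain. In a functional assay (trachea) for antagonist activity, with Cavia porcellus as the target (a higher number here means a weaker inhibitor, a lower number a stronger inhibitor), compound 1 gives 10000 nM and compound 2 gives 7200 nM; the two numbers lie within the scatter of each other, so no order between them is claimed. Compound 3 `CCCCCCCCCCCC/C=C\[C@H](SC[C@H](N)C(=O)NCC(=O)O)[C@H](O)CCCO` is not yet measured; it carries hydroxymethyl in place of carbamoyl on a saturated chain carbon, three bonds along the chain from an oxygen on a saturated carbon. For the measured compounds named here, no comparable step is available among the measured pairs. The step from compound 2 to compound 3 is expected to be a 1.4-fold higher number from compound 2 to compound 3 (0.14 log units; within the scatter), no more than the scatter. Compound 3 is therefore estimated at 10000 nM in this assay, in the range 3000 nM to 30000 nM.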

Compound 3, antagonist equilibrium constant: 14000 nM
The estimate for compound 3 lay 1.4-fold (0.15 log units) below the measured number, within the range that was stated.
By their numbers in this assay, from the lowest: compounds 2, 1 and 3 (each within the scatter of the next).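

Replacing carbamoyl with hydroxymethyl on a saturated chain carbon, three bonds along the chain from an oxygen on a saturated carbon, gives a 1.9-fold higher number from compound 2 to compound 3 (0.29 log units; within the scatter) in this assay. This position therefore tolerates this change without a step beyond the scatter, although the group loses its carbonyl and nitrogen while the counts of hydrogen-bond donors and acceptors stay equal. Nothing available bears on the cause of this step. On these data alone, whether an amine or a longer chain here would move the number beyond the scatter remains open.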